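Aromatic groups at the saturated ring carbon of the core

This account rests on a few compounds, and the source may have more. Where it says the series, first, only, none or still open, it means among the compounds named here.

Measured so far:
compound 1, `CCC1C(=O)N(C)c2cnc(Nc3ccc(S(N)(=O)=O)cc3)nc2N1C`: 479 nM
compound 2, `Cc1ccc(F)cc1C1C(=O)N(C)c2cnc(Nc3ccc(S(N)(=O)=O)cc3)nc2N1C`: 168 nM
Not yet measured:
compound 3, `CN1C(=O)C(Cc2ccccc2)N(C)c2nc(Nc3ccc(S(N)(=O)=O)cc3)ncc21`

In an assay on Sf9 cells for inhibition of serine/threonine-protein kinase 4 (Homo sapiens), read by luminescence and ADP-Glo, with a stated time of 1 h, in the presence of a further agent that is not named here (on this read-out higher numbers stand for weaker inhibition and lower numbers for stronger inhibition), compound 1 gives 479 nM and stands highest of the two numbers shown; its nearest neighbour is compound 2, reached by a 2.9-fold lower number from compound 1 to compound 2 (0.46 log units; beyond the scatter), a modest step that lies beyond the scatter. The change to compound 3 is phenyl in place of methyl on a saturated chain carbon bound to a saturated ring carbon. Among the compounds with values here, the one measured step that bears on it is a 2.9-fold lower number from compound 1 to compound 2 (0.46 log units; beyond the scatter), where an aromatic ring also enters in place of the ethyl on the saturated ring carbon; in compound 3 the phenyl is carried one bond further out, on the chain carbon, and the aromatic ring is unsubstituted, so the resemblance is partial. On that basis a step in the same direction is expected, of similar or somewhat smaller size, a 1.9-fold lower number from compound 1 to compound 3 (0.28 log units; within the scatter), with real uncertainty whether it clears the scatter. For compound 3 the estimate is 250 nM, with a range from 100 nM to 600 nM.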

Compound 3, half-maximal inhibitory concentration: > 10000 nM
Compound 3: a limit, no number; the forecaster's own chance of this, stated with the estimate: 2%; middle value at least 40-fold (1.60 log units) from the limit.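

In this assay compound 3 carries a limit of the assay and not a number: the limit of > 10000 nM in this assay, at which 1 of the 3 values shown sits.

Benzyl at this position is therefore far less well accepted than either earlier group, with an at least 20-fold higher number from compound 1 to compound 3 (1.31 log units; beyond the scatter) and an at least 59-fold higher number from compound 2 to compound 3 (1.77 log units; beyond the scatter). The earlier pair alone suggested that an aromatic ring on the saturated ring carbon was at least compatible with inhibition, but the presence of an aromatic ring does not settle the outcome here: compound 2 carries a 5-fluoro-2-methylphenyl on the saturated ring carbon and stays measurable, while compound 3 carries a phenyl on a saturated chain carbon bound to that ring carbon and reaches the limit.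

The step from compound 2 to compound 3 changes both the ring substituents and the attachment, so the compounds shown do not separate the contribution of the fluorine and methyl from that of the chain carbon. Also open, from the compounds shown here alone, are how an unsubstituted phenyl on the saturated ring carbon would read, and whether a propyl chain, an aminomethyl group or a carboxylic acid at this position would be accepted.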